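Compound 3 to compound 4: ethoxy to methoxy

The source may hold more compounds than are shown below. What is called first, only, known or untested is meant among the compounds shown, and "the series" means these compounds.

In a functional assay on MCF7 cells (Homo sapiens) for inhibition, read by sulforhodamine B assay (on this read-out higher numbers stand for weaker inhibition and lower numbers for stronger inhibition), compound 1 `CCCc1ccc(NC2=CC(=O)c3nc4n(c3C2=O)[C@H]2OC[C@@H](O)[C@H]2OC4)cc1` gives 4660 nM, and compound 3 `CCOc1ccc(NC2=CC(=O)c3nc4n(c3C2=O)[C@H]2OC[C@@H](O)[C@H]2OC4)cc1` gives 1430 nM. Compound 2 `O=C1C=C(NC2CCCCC2)C(=O)c2c1nc1n2[C@H]2OC[C@@H](O)[C@H]2OC1` is recorded only as a limit, > 8000 nM. Compound 3 therefore has the lower of the two actual numbers.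

Compound 4 `COc1ccc(NC2=CC(=O)c3nc4n(c3C2=O)[C@H]2OC[C@@H](O)[C@H]2OC4)cc1` differs from compound 3 by hydrogen in place of methyl on a saturated chain carbon bound to an oxygen on an aromatic ring, which reads as ethoxy to methoxy.

The closest measured change is ethoxy in place of propyl on an aromatic carbon, a 3.3-fold lower number from compound 1 to compound 3 (0.51 log units; beyond the scatter). The two cyclohexyl steps, an at least 1.7-fold higher number from compound 1 to compound 2 (0.23 log units; that floor lies within the scatter) and an at least 5.5-fold lower number from compound 2 to compound 3 (0.74 log units; beyond the scatter), exchange the whole substituted phenyl group and bear on this change only loosely. For the measured compounds named here, no measured step trims this ether chain, so the direction stays open. Against the modest 3.3-fold lower number from compound 1 to compound 3 (0.51 log units; beyond the scatter), a smaller step is expected in this assay, probably within the scatter. The estimated step is a 1.3-fold higher number from compound 3 to compound 4 (0.10 log units; within the scatter). For compound 4 the expected value is 1800 nM, with an estimated range of 800 nM to 4200 nM.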

Compound 4, half-maximal inhibitory concentration: 5420 nM
The estimate for compound 4 lay 3.0-fold (0.48 log units) below the measured number, outside the stated range (above it).
By their numbers in this assay, from the lowest: compound 3; then compounds 1 and 4 (each within the scatter of the next). At a limit, above all of these: compound 2.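

In this assay, trimming ethoxy to methoxy gives a 3.8-fold higher number from compound 3 to compound 4 (0.58 log units; beyond the scatter), so the loss of one methyl on this ether chain is enough for a modest step. The methoxy compound does not separate from the propyl compound, with a 1.2-fold higher number from compound 1 to compound 4 (0.07 log units; within the scatter), so the earlier drop from propyl to ethoxy does not carry over to every ether here, and among compound 1, compound 3 and compound 4 only compound 3 stands apart. The remaining step, an at least 1.4-fold lower number from compound 2 to compound 4 (0.16 log units; that floor lies within the scatter), rests on a limit and fixes no order: the limit of > 8000 nM in this assay, at which 1 of the 4 values shown sits.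

Open, going by these compounds, is whether a longer chain on the same oxygen, such as propoxy or butoxy, would lower the number further or raise it again. Also open, on these data alone, is where a 4-hydroxyphenyl group, with no chain on that oxygen, would fall.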